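This account rests on a few compounds, and the source may have more. Where it says the series, first, only, none or still open, it means among the compounds named here.

Working notes on a small set of 2-aryl indole analogues tested in an assay on isolated protein for inhibition of Aromatase (Homo sapiens), read by fluorescence, using NADPH, with a stated time of 30 min, tested at 50 uM; a higher number here means more inhibition at the concentration tested (going by the name of the read-out), a lower number less inhibition.

Compound 1 `Cn1c(-c2ccc(Cl)c(Cl)c2)cc2ccccc21` gives 20% in this assay. Compound 2 `Brc1ccc(-c2cc3ccccc3[nH]2)cc1` gives 4.8% in this assay, and compound 3 `CC(C)(C)OC(=O)n1c(-c2ccccc2)cc2ccccc21` gives 11.9% in this assay. Among the three numbers measured, compound 2 stands lowest. Its nearest neighbour is compound 3, whose number lies higher by an amount that stays within the scatter, so no order between compound 2 and compound 3 is claimed. The furthest is compound 1, whose number lies higher by an amount beyond the scatter. Going by the values given here, compound 1 and compound 3 differ from compound 2 in more than one place, so no single step between measured compounds is available.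

The next analogue is compound 4 `Nc1ccc(-c2cc3ccccc3[nH]2)cc1`, which is still to be measured in this assay. Its relation to compound 2 is a single change: amino in place of bromo on an aromatic carbon. Among the compounds with values here, nothing among the measured compounds shows the effect of an amino in place of a bromo at this position, so the expectation rests on the low level of compound 2 alone.

The step from compound 2 to compound 4 is expected to be small, within the scatter, a number 5.2 percentage points higher from compound 2 to compound 4 (within the scatter). Compound 4 is thus estimated at 10% in this assay, with a range from 0% to 28%.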

Compound 4, a percentage reported as inhibition, at one concentration (the size of the read-out at that concentration, not a potency): 46.2%
The estimate for compound 4 lay 36.2 percentage points below the measured number, outside the stated range (above it).
By their numbers in this assay, from the lowest: compounds 2, 3 and 1 (each within the scatter of the next, the first and the last beyond it); then compound 4.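

In this assay, going by these compounds alone, amino in place of bromo on an aromatic carbon gives a number 41.4 percentage points higher from compound 2 to compound 4 (beyond the scatter), the first single-place change that can be read, and it shows that the outcome at this position depends strongly on the group it carries. The swap is small by count: one heavy atom leaves, one enters, neither group has a ring or a net charge, and the counted difference is the hydrogen-bond donor and hydrogen-bond acceptor that amino brings and bromo lacks. That count describes the change and does not explain it, as no measurement here addresses what lies behind the step.

The compounds shown leave open whether the step depends on the amino group itself or on the loss of bromo, a question that a hydrogen, a hydroxyl, a methoxy, a dimethylamino or an acetamido group at the same place could help to separate. They also leave open whether amino would give a step of similar size on the core of compound 1 or compound 3, where the indole nitrogen carries a methyl or a tert-butoxycarbonyl group.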